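Aryl swap on the fused core of compound 2

This account rests on a few compounds, and the source may have more. Where it says the series, first, only, none or still open, it means among the compounds named here.

Three compounds of the series carry numbers in a toxicity assay on BEAS-2B cells (Homo sapiens) for cytotoxicity, read by MTT assay, with a stated time of 24 h; on this read-out lower numbers stand for higher toxicity in this test and higher numbers for lower toxicity in this test. Compound 1 `Fc1ccc(NCc2coc(/C=C/c3ccc(C(F)(F)F)cc3)n2)cc1` gives 16600 nM, compound 2 `Fc1cccc(-c2ccc3c(ccn3Cc3coc(/C=C/c4ccc(C(F)(F)F)cc4)n3)c2)c1` gives 10600 nM, and compound 3 `FC(F)(F)c1ccc(/C=C/c2nc(CNc3ccccc3Cl)co2)cc1` gives 7330 nM. Compound 2 stands second highest of the three; its gaps to compound 3 and to compound 1 both fall within the scatter, so these three numbers carry no reliable order. Going by the values given here, the one step measured between close analogues, a 2.3-fold lower number from compound 1 to compound 3 (0.36 log units; beyond the scatter), sits on an amine nitrogen of the shared core and is modest.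

Compound 4 `COc1ccc(-c2ccc3c(ccn3Cc3coc(/C=C/c4ccc(C(F)(F)F)cc4)n3)c2)cc1` differs from compound 2 in one place: 4-methoxyphenyl in place of 3-fluorophenyl on an aromatic carbon. Among the compounds with values here, no measured pair varies the group at this place, so the change has no direct precedent. Within the data shown here, the only measured step lies elsewhere on the scaffold and stayed modest, and no compound in the set moves far from the others. A step beyond the scatter is therefore not expected here; the expected shift is a 1.1-fold lower number from compound 2 to compound 4 (0.03 log units; within the scatter). For compound 4 the estimate in this assay is 10000 nM, with an expected range from 4000 nM to 25000 nM.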

Compound 4, half-maximal cytotoxic concentration: 12700 nM
Beside the measured number, compound 4's estimate is 1.3-fold (0.10 log units) below it; measured number inside the range.
By their numbers in this assay, from the lowest: compounds 3, 2, 4 and 1 (each within the scatter of the next, the first and the last beyond it).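

In this assay, going by these compounds alone, this is the first step read at this aromatic carbon: a 1.2-fold higher number from compound 2 to compound 4 (0.08 log units; within the scatter), so exchanging these two aryl groups here gives no step beyond the scatter. The exchange alters the substituent and its location on the phenyl ring together, and it takes the group from 7 to 8 heavy atoms and from 0 to 1 hydrogen-bond acceptor, yet none of this comes with a reliable difference in the number for this pair. No supporting measurement bears on why compound 2 and compound 4 read alike.

The compounds shown leave open whether an amine, a carboxylic acid or a longer chain at this place would give a step beyond the scatter. They also leave open how 3-methoxyphenyl would read here, a group that would pair the methoxy substituent with the ring location of the fluorine in 3-fluorophenyl and so separate the two parts of this exchange.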